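The source may report more compounds than this note shows. Statements on the series, on what has been measured and on what is new or still open speak of the compounds shown alone.

Measured so far in an ADME assay on microsomes from liver (Homo sapiens) for metabolic stability, read by LC-MS, using NADPH, with a stated time of 30 min, tested at 0.5 uM; a higher number here means faster removal of the compound, a lower number slower removal:
Compound 1 `CC(C)(C)c1ccc(CN2CCC3(CC2)OCCc2sccc23)cc1`: 9.9 mL/min/g
Compound 2 `FS(F)(F)(F)(F)c1ccc(CN2CCC3(CC2)OCCc2sccc23)cc1`: 3 mL/min/g

Among the compounds with values here, on these two numbers compound 2 stands lowest, with compound 1 as its only neighbour. The next compound, compound 3 `c1ccc(Oc2ccc(CN3CCC4(CC3)OCCc3sccc34)cc2)cc1`, carries a group of 7 heavy atoms (6 carbon, 1 oxygen; one six-membered aromatic ring of carbon only) in place of a group of 6 heavy atoms (5 fluorine, 1 sulfur; no ring), on an aromatic carbon. Within the data shown here, one measured step concerns an exchange at the same place: a 3.3-fold lower number from compound 1 to compound 2 (0.52 log units; beyond the scatter). That step shows a swap here can move this assay beyond the scatter, but its entering group differs from the phenoxy, so its direction cannot simply be copied. For compound 3 a rise back toward the level of compound 1 is expected, estimated as a 2.7-fold higher number from compound 2 to compound 3 (0.43 log units; beyond the scatter). Compound 3 is therefore estimated at 8 mL/min/g, within a range from 3.5 mL/min/g to 18 mL/min/g.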

Compound 3, intrinsic clearance in a liver preparation (reported as CLH), per the amount of preparation that the assay uses: 12 mL/min/g
The estimate for compound 3 lay 1.5-fold (0.18 log units) below the measured number; the range from low to high includes it.
By their numbers in this assay, from the lowest: compound 2; then compounds 1 and 3 (each within the scatter of the next).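

In this assay the low number of compound 2 does not carry over to phenoxy, which brings a 4.0-fold higher number from compound 2 to compound 3 (0.60 log units; beyond the scatter) in place of the group of 5 fluorine and 1 sulfur. Phenoxy and tert-butyl cannot be told apart at this place, with a 1.2-fold higher number from compound 1 to compound 3 (0.08 log units; within the scatter) between them, so among these three compounds only compound 2 stands apart. Nothing available explains this difference. Still open, as far as these compounds go, is whether an amine or a carboxylic acid on this aromatic carbon would sit with compound 2 or with the other two.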